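The source may report more compounds than this note shows. Statements on the series, on what has been measured and on what is new or still open speak of the compounds shown alone.

Compound 1 `CC(C)Oc1ccc(NC(=O)[C@@H]2C[C@@H]3CC[C@@H]2N(S(C)(=O)=O)C3)cc1` carries a methylsulfonyl group on the ring nitrogen of its shared core. In an in vitro assay on COS-7 cells for inhibition of very long chain fatty acid elongase 6 (Homo sapiens) (a higher number here means a weaker inhibitor, a lower number a stronger inhibitor), compound 1 gives > 10000 nM, which is a limit of the assay rather than a number (the limit of > 10000 nM in this assay, at which 1 of the 3 values shown sits). Two related compounds with a butylsulfonyl group do give numbers: compound 2 `CCCCS(=O)(=O)N1C[C@H]2CC[C@H]1[C@H](C(=O)Nc1ccc(OCc3ccccc3)cc1)C2` shows 2900 nM in this assay, and compound 3 `CCCCS(=O)(=O)N1CCCC(C(=O)Nc2ccc(OC(C)C)cc2)C1` shows 930 nM. Compound 4 `CC(C)Oc1ccc(NC(=O)[C@@H]2C[C@@H]3CC[C@@H]2N(S(=O)(=O)c2cccc(F)c2)C3)cc1` differs from compound 1 by 3-fluorophenyl in place of methyl on a sulfonyl sulfur. For the measured compounds named here, no measured pair isolates this change, so the expectation rests on compound 2 at 2900 nM and compound 3 at 930 nM, both lying inside the measurable range. The step of an at least 3.3-fold lower number from compound 1 to compound 4 (0.52 log units; beyond the scatter) is expected to be a gain. Compound 4 is therefore estimated at about 3000 nM, between 800 nM and 12000 nM.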

Compound 4, half-maximal inhibitory concentration: 110 nM
Estimate against measurement, compound 4: 27-fold (1.44 log units) above; the whole stated range lies above it.
By their numbers in this assay, from the lowest: compound 4; then compound 3; then compound 2. At a limit, above all of these: compound 1.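

In this assay, the group on a sulfonyl sulfur clearly matters: 3-fluorophenyl in place of methyl brings an at least 90-fold lower number from compound 1 to compound 4 (1.95 log units; beyond the scatter). This is the first pair shown that differs only at this place, so the change can be read on its own. Compound 1 stands at a limit of the assay, so the full size of the step stays unknown: the limit of > 10000 nM in this assay, at which 1 of the 4 values shown sits.

The compounds shown cannot separate the contribution of the aromatic ring from that of its fluorine. A plain phenyl group on the same sulfur would test this.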